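Cytotoxicity of Chlorophenyl Amide Pyrimidines in MT4 Cells

A few compounds are considered here, and "the series" means these few. Any claim that something is new, unique, unknown or untested is made for them only; others in the source may bear on it.

Three compounds were measured in an ADME assay on MT4 cells (Homo sapiens) for cytotoxicity, read by MTT assay, with a stated time of 5 days; on this read-out lower numbers stand for higher toxicity in this test and higher numbers for lower toxicity in this test:

Compound 1 `N#Cc1ccc(Nc2nccc(OCC(=O)Nc3ccc(Cl)cc3)n2)cc1` gives 162000 nM.
Compound 2 `N#Cc1ccc(Nc2nccc(OCC(=O)Nc3cccc(Cl)c3)n2)cc1` reaches only a limit of the assay, > 329000 nM.
Compound 3 `Cc1cnc(Nc2ccc(C#N)cc2)nc1OCC(=O)Nc1ccc(Cl)cc1` also reaches only a limit of the assay, > 317000 nM.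

Compound 1 and compound 2 differ in one place: 3-chlorophenyl in place of 4-chlorophenyl on an amide-type nitrogen. The step of an at least 2.0-fold higher number from compound 1 to compound 2 (0.30 log units; that floor lies within the scatter) rests on the limit (the limit of > 329000 nM in this assay, at which 1 of the 3 values shown sits), so its true size is not known. Compound 3 differs from compound 1 elsewhere: methyl in place of hydrogen on an aromatic carbon. The step of an at least 1.9-fold higher number from compound 1 to compound 3 (0.29 log units; that floor lies within the scatter) rests on the limit (the limit of > 317000 nM in this assay, at which 1 of the 3 values shown sits).

Compound 4 `Cc1cnc(Nc2ccc(C#N)cc2)nc1OCC(=O)Nc1cccc(Cl)c1` has not been measured. It differs from compound 3 as 3-chlorophenyl in place of 4-chlorophenyl on an amide-type nitrogen, the same change that leads from compound 1 to compound 2. The step from compound 3 to compound 4 is expected to be about a step that the limit leaves unreadable from compound 3 to compound 4, since the measured compound 3 already sits at a limit and the same change from compound 1 to compound 2 gave an at least 2.0-fold higher number from compound 1 to compound 2 (0.30 log units; that floor lies within the scatter). Compound 4 is therefore estimated at 450000 nM in this assay, most likely again only as a limit, within 200000 nM to 1200000 nM.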

Compound 4, half-maximal cytotoxic concentration: 144000 nM
Compound 4: the middle estimate sits 3.1-fold (0.49 log units) above what was measured; measured number below the stated range.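

Changing 4-chlorophenyl to 3-chlorophenyl on an amide-type nitrogen gives, in this assay, an at least 2.2-fold lower number from compound 3 to compound 4 (0.34 log units; beyond the scatter), so this change does not repeat its earlier effect on the second core: the same change on two cores in this assay, an at least 2.0-fold higher number (0.30 log units; that floor lies within the scatter) from compound 1 to compound 2 and an at least 2.2-fold lower number (0.34 log units; beyond the scatter) from compound 3 to compound 4, at least 4.4-fold (0.65 log units) apart, beyond the scatter of two such steps. Adding methyl in place of hydrogen on an aromatic carbon gives an at least 2.2-fold lower number from compound 2 to compound 4 (0.35 log units; beyond the scatter), so this change does not carry over unchanged either: the same change on two cores in this assay, an at least 1.9-fold higher number (0.29 log units; that floor lies within the scatter) from compound 1 to compound 3 and an at least 2.2-fold lower number (0.35 log units; beyond the scatter) from compound 2 to compound 4, at least 4.4-fold (0.65 log units) apart, beyond the scatter of two such steps. Compound 2 and compound 3 are known only as limits of the assay, so these comparisons show that neither change acts as a fixed shift across the two cores, but they do not show the true size of any step or explain the difference.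

The compounds shown leave open how an ethyl group in place of the methyl, or a fluorine atom or methoxy group in place of the chlorine, would behave in this test. They also leave open how either change would behave on any further core.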